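The source may report more compounds than this note shows. Statements on the series, on what has been measured and on what is new or still open speak of the compounds shown alone.

Measured so far:
- compound 1, `CC(=O)NC/C=C\CN(C)C[C@H]1O[C@@H](n2cnc3c(N)ncnc32)[C@H](O)[C@@H]1O`: > 1.5 h
- compound 2, `CN(C/C=C\CN)C[C@H]1O[C@@H](n2cnc3c(N)ncnc32)[C@@H]2OC(C)(C)O[C@@H]21`: > 1.5 h

Both compounds share the same core and were examined in an ADME assay on microsomes from liver (Homo sapiens) for metabolic stability, read by LC-MS, using NADPH, tested at 1 uM; on this read-out higher numbers stand for a longer-lived compound and lower numbers for a shorter-lived compound. For compound 1 the reading of > 1.5 h is a limit of the assay rather than a number. For compound 2 the reading of > 1.5 h is likewise a limit, not a number. Compound 2 thus stands at the limit of > 1.5 h in this assay, at which 2 of the 2 values shown sit, and the two readings cannot be ranked against each other. Among the measured compounds shown here, no step between measured compounds can be drawn from them.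

Compound 3, `CCCCCCCCC(=O)Nc1ncnc2c1ncn2[C@@H]1O[C@H](CN(C)C/C=C\CN)[C@H]2OC(C)(C)O[C@H]21`, has yet to be measured in this assay. It differs from compound 2 in one place: octylcarbonyl in place of hydrogen on a nitrogen on an aromatic ring. For the measured compounds named here, with no measured step to lean on, the change is expected to amount to an at least 1.2-fold lower number from compound 2 to compound 3 (0.09 log units; that floor lies within the scatter), meaning at most a small shortening that may well stay within the scatter. Compound 3 is therefore expected to come out at about 1.2 h in this assay, somewhere between 0.4 h and 3 h.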

Compound 3, half-life: 0.162 h
Compound 3: middle estimate off by 7.4-fold (0.87 log units), on the high side, outside the stated range (below it).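

The earlier compounds shown here gave only limits in this assay, so they could not show whether any change in structure shortens the half-life. Here, turning the amino group into an (octylcarbonyl)amino group, with octylcarbonyl in place of hydrogen on a nitrogen on an aromatic ring, gives an at least 9.2-fold lower number from compound 2 to compound 3 (0.96 log units; beyond the scatter), so this position is not indifferent to what is attached there. The real step may be larger than this floor, because compound 2 is known only as a limit: the limit of > 1.5 h in this assay, at which 2 of the 3 values shown sit.

The compounds shown leave open whether the length of the chain or the new carbonyl link itself accounts for the shorter half-life. A shorter chain such as butanoyl, or a chain ending in a carboxylic acid, on the same nitrogen would help separate the two.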